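The source may report more compounds than this note shows. Statements on the series, on what has been measured and on what is new or still open speak of the compounds shown alone.

Compound 3 `CC(=O)O[C@]12C=CC(O)C[C@H]1OCC2` carries an acetyl ester on the shared core, with a free hydroxyl on the ring. In a functional assay on P388 cells (Mus musculus) for cytotoxicity (a higher number here means a weaker inhibitor, a lower number a stronger inhibitor), compound 3 gives only > 100 ug/mL, which is a limit of the assay rather than a number. Its nearest measured neighbour is compound 2 `OC1C=C[C@]2(O)CCO[C@@H]2C1`, which has a hydrogen where compound 3 has the acetyl; compound 2 gives 40.8 ug/mL in this assay. The step of an at least 2.4-fold higher number from compound 2 to compound 3 (0.38 log units; beyond the scatter) thus shows that adding the acetyl weakened the compound, and the size of that step is set by the limit of > 100 ug/mL in this assay, at which 1 of the 3 values shown sits. For the measured compounds named here, compound 1 `CCCCCC(=O)O[C@]12C=CC(=O)C[C@H]1OCC2` differs in two places at once, carrying a hexanoyl ester and a ketone instead of the hydroxyl, and gives 0.3 ug/mL in this assay; no single step connects it to compound 3.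

Compound 4 `CCCC(=O)O[C@]12C=CC(O)C[C@H]1OCC2` is the next compound to be tested. It differs from compound 3 by ethyl in place of hydrogen on a saturated chain carbon bound to a carbonyl carbon. No measured step changes the length of the acyl chain on its own, so nothing shown tells the direction this change should take. Compound 4 is therefore expected to remain weak in this assay, with an estimate of 70 ug/mL, ranging from 15 ug/mL to 250 ug/mL, which would mean an estimated step of an at least 1.4-fold lower number from compound 3 to compound 4 (0.15 log units; that floor lies within the scatter).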

Compound 4, half-maximal inhibitory concentration: > 100 ug/mL
Compound 4: a limit, no number (the forecaster's own chance of this, stated with the estimate: 45%); middle value at least 1.4-fold (0.15 log units) away from the limit.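

The propylcarbonyl ester gives an at least 2.4-fold higher number from compound 2 to compound 4 (0.38 log units; beyond the scatter), so the weakening first seen with acetyl now appears with a second ester on the same oxygen. Lengthening the acetyl to propylcarbonyl, with the free hydroxyl kept, does not bring the compound back to a measurable number in this assay, which is the one new thing this change shows about the chain. Its true size cannot be read, since compound 3 and compound 4 each give only a limit, and the ceiling of the assay now governs more of the data: the limit of > 100 ug/mL in this assay, at which 2 of the 4 values shown sit.

The compounds shown do not separate the effect of a still longer chain on this ester from that of a ketone in place of the free hydroxyl, since compound 1 differs from compound 3 and compound 4 in both places at once. Also open, on these data alone, is what happens on this oxygen with a group of another kind, such as an amine-bearing chain in place of the plain acyl chain.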